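Triazole N-aryl swap in the spiro series: compound 4 outlook

The source may report more compounds than this note shows. Statements on the series, on what has been measured and on what is new or still open speak of the compounds shown alone.

Compound 3 `Cc1ccc(C)c(-n2nncc2CN2C(=O)C3(C(C#N)=C(N)Oc4c(N)cc5nc6ccccc6nc5c43)c3ccccc32)c1` sits at a limit in a functional assay on A549 cells (Homo sapiens) for antiproliferative activity, read by MTT assay, with a stated time of 48 h (a lower number here means a stronger inhibitor, a higher number a weaker inhibitor), giving > 50000 nM. Compound 1 `Cc1cccc(-n2nncc2CN2C(=O)C3(C(C#N)=C(N)Oc4c(N)cc5nc6ccccc6nc5c43)c3ccccc32)c1` gives 12300 nM. Compound 2 `CC(=O)Nc1ccc(-n2nncc2CN2C(=O)C3(C(C#N)=C(N)Oc4c(N)cc5nc6ccccc6nc5c43)c3ccccc32)cc1` also returns only a limit, > 50000 nM. The measured steps run an at least 4.0-fold higher number from compound 1 to compound 3 (0.60 log units; beyond the scatter) and an at least 4.0-fold higher number from compound 1 to compound 2 (0.60 log units; beyond the scatter), while a step that the two limits leave unreadable from compound 2 to compound 3; the limit of > 50000 nM in this assay, at which 2 of the 3 values shown sit, frames both limits. Compound 4 `N#CC1=C(N)Oc2c(N)cc3nc4ccccc4nc3c2C12C(=O)N(Cc1cnnn1-c1c(F)cccc1F)c1ccccc12` differs from compound 3 by 2,6-difluorophenyl in place of 2,5-dimethylphenyl on an aromatic nitrogen. For the measured compounds named here, no measured step touches a fluorinated aryl, and the only aryl changes seen moved numbers upward from compound 1 toward the limit. Compound 4 is therefore expected to stay near the limit, with an at least 1.2-fold lower number from compound 3 to compound 4 (0.09 log units; that floor lies within the scatter) as the estimated step. The estimate for compound 4 is 40000 nM, in the range 12000 nM to 120000 nM.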

Compound 4, half-maximal inhibitory concentration: > 50000 nM
Compound 4: a limit, no number (the forecaster's own chance of this, stated with the estimate: 55%); middle value at least 1.2-fold (0.09 log units) from the limit.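

In this assay, the 2,6-difluorophenyl group on the aromatic nitrogen, the first fluorinated aryl in the set, does not match the 3-methylphenyl group of compound 1, with an at least 4.0-fold higher number from compound 1 to compound 4 (0.60 log units; beyond the scatter). The steps from compound 2 and compound 3 to compound 4 cannot be read, as both ends of each are limits. For the compounds shown here, compound 1 remains the only compound with a number, and the other three aryl groups share one limit: the limit of > 50000 nM in this assay, at which 3 of the 4 values shown sit.

As far as these compounds go, the order among compound 2, compound 3 and compound 4 stays open. Also open, from the compounds shown here alone, is how a phenyl ring carrying an aminomethyl group or a carboxylic acid would read in this assay.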